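The compounds below may be only part of what the source reports. "The series", "measured", "known", "first", "only" and "open" are said of these compounds alone.

In a functional assay on PC-3 cells (Homo sapiens) for inhibition, read by MTT assay, with a stated time of 72 h (a lower number here means a stronger inhibitor, a higher number a weaker inhibitor), compound 1, `CC(C)=CCC/C(C)=C/COc1ccc(C2CC2C(=O)NNC(=O)c2ccncc2)cc1`, gives only a limit, > 100000 nM. Going by the values given here, compound 2, `O=C(NNc1nncc2ccccc12)C1CC1c1ccc(OCC(F)(F)F)cc1`, is the one other compound measured; in this assay compound 2 gives 67000 nM. Of the pair, the two values show compound 2 with a number and compound 1 with only a limit, and nothing more can be said of them together. Compound 3, `COc1ccc(C2CC2C(=O)NNC(=O)c2ccncc2)cc1`, is not yet measured. It differs from compound 1 in one place: hydrogen in place of 2,6-dimethylhepta-1,5-dien-1-yl on a saturated chain carbon bound to an oxygen on an aromatic ring, so the shared core stays as it is and only the chain on the oxygen on the aromatic ring is cut back. Among the compounds with values here, no step between measured compounds tells the size of such a change, and with compound 1 sitting at the limit of > 100000 nM in this assay, at which 1 of the 2 values shown sits, the direction cannot be read either; no step beyond the scatter is expected in this assay. Compound 3 is therefore estimated at 100000 nM in this assay, within 30000 nM to 300000 nM. The expected step is a number no higher from compound 1 to compound 3 (the limit leaves the size open).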

Compound 3, half-maximal inhibitory concentration: > 100000 nM
Compound 3 was reported as a limit; the forecaster's own chance of this, stated with the estimate: 60%; the middle value lies on the limit itself.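

Compound 1 and compound 3 are both reported only as a limit in this assay, so no new step can be read between them: the limit of > 100000 nM in this assay, at which 2 of the 3 values shown sit.

The compounds shown leave open whether hydrogen in place of 2,6-dimethylhepta-1,5-dien-1-yl changes the result in this assay at all, and in which direction.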